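Thiophene for furan on a nucleoside core

This account rests on a few compounds, and the source may have more. Where it says the series, first, only, none or still open, it means among the compounds named here.

Compound 1, `O=c1[nH]cnc2c1c(-c1ccoc1)cn2[C@@H]1O[C@H](CO)[C@@H](O)[C@H]1O`: 9030 nM
Compound 2, `CN(C)c1ncnc2c1c(-c1ccoc1)cn2[C@@H]1O[C@H](CO)[C@@H](O)[C@H]1O`: 13300 nM

In a functional assay on CCRF-CEM cells (Homo sapiens), read by MTT assay, with a stated time of 72 h (on this read-out lower numbers stand for stronger inhibition and higher numbers for weaker inhibition), compound 1 gives 9030 nM, and compound 2 gives 13300 nM; the two numbers lie within the usual scatter of each other, so neither can be called the more potent. Compound 3, `O=c1[nH]cnc2c1c(-c1cccs1)cn2[C@@H]1O[C@H](CO)[C@@H](O)[C@H]1O`, is not yet measured. It differs from compound 1 in one place: thiophen-2-yl in place of furan-3-yl on an aromatic carbon. Among the compounds with values here, the swap keeps the ring size and the count of hetero atoms, donors and acceptors, and no measured pair shows what such a change does here. Only a small step is expected, none beyond the scatter, so that a 1.1-fold lower number from compound 1 to compound 3 (0.03 log units; within the scatter) is the expected change. Compound 3 is therefore estimated at 8500 nM, within 3000 nM to 25000 nM.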

Compound 3, half-maximal inhibitory concentration: > 20000 nM
Compound 3 gave a limit, no number; the forecaster's own chance of this, stated with the estimate: 10%; middle value at least 2.3-fold (0.37 log units) away from the limit.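

In this assay compound 3 gives > 20000 nM as a limit of the assay and not a number. Even so, thiophen-2-yl in place of furan-3-yl gives an at least 2.2-fold higher number from compound 1 to compound 3 (0.34 log units; beyond the scatter) and so shows that this aromatic carbon is sensitive to which ring it carries, although both rings have the same heavy-atom count and the same counts of donors and acceptors. The true size of the step stays unread: the limit of > 20000 nM in this assay, at which 1 of the 3 values shown sits.

This single pair cannot separate the change from oxygen to sulfur from the change in how the ring is attached. Thiophen-3-yl, which could separate them, and an amine on this carbon remain open.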